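Replacing Methyl with Phenyl on a Sulfur-Bound Carbon

A few compounds are considered here, and "the series" means these few. Any claim that something is new, unique, unknown or untested is made for them only; others in the source may bear on it.

Of the compounds shown here, three built on one shared core have been tested in a functional assay on the whole organism (strain NMRI) with Mus musculus as the target, with a stated time of 60 min, at a dose of 20 mg/kg by the intraperitoneal route; on this read-out higher numbers stand for a stronger effect at the one dose given and lower numbers for a weaker effect. Compound 1 `S=c1[nH]nc(Cc2ccccc2Oc2ccccc2)[nH]1` gives 160%. Compound 2 `S=c1[nH]nc(Cc2ccc(Cl)cc2Oc2ccccc2Cl)[nH]1` gives 159%. Compound 3 `CCSc1nnc(Cc2ccccc2Oc2ccccc2)[nH]1` gives 169% in this assay; this is the highest of the three numbers, but its distance to compound 1 and to compound 2 lies within the usual scatter of repeated measurements, so the three cannot be told apart on these data.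

Compound 4 `c1ccc(CSc2nnc(Cc3ccccc3Oc3ccccc3)[nH]2)cc1` has not yet been measured. It differs from compound 3 in a single place: phenyl in place of methyl on a saturated chain carbon bound to a sulfur. Going by the values given here, no pair of measured compounds shows what this particular change does. All that the measured numbers say about the part of the structure that changes is that compound 1 and compound 3, which differ there, sit within the scatter of each other. With nothing pointing up or down, the expectation for compound 4 is a number close to that of compound 3.

Compound 4 is therefore expected to give 160%, with a range from 120% to 200%. This estimate means a step of a number 9 percentage points lower from compound 3 to compound 4 (within the scatter), which is no step beyond the scatter.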

Compound 4, a percentage reported as activity, at one dose (the size of the read-out at that dose, not a potency): 143%
The estimate for compound 4 lay 17 percentage points above the measured number; measured number inside the range.
By their numbers in this assay, from the lowest: compound 4; then compounds 2, 1 and 3 (each within the scatter of the next).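

In this assay, phenyl in place of methyl on a saturated chain carbon bound to a sulfur, which turns ethylsulfanyl into benzylsulfanyl, gives a number 26 percentage points lower from compound 3 to compound 4 (beyond the scatter). Going by these compounds alone, this is the first change in this part of the structure that exceeds the scatter, since compound 1 at 160% and compound 3 at 169% could not be told apart, so what sits on the sulfur can alter the read-out at this one dose, although this single pair shows only a modest step. Nothing measured for these compounds bears on why the number falls with benzylsulfanyl in place of ethylsulfanyl.

From the compounds shown here alone, it remains open whether a longer chain such as propyl or butyl on the sulfur, or an amine at the end of the ethyl chain, would stay close to compound 3 or fall as compound 4 does. It is also unknown whether the same exchange of methyl for phenyl would give a similar step on the chlorine-bearing framework of compound 2, or whether it is tied to the framework of compound 3.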